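The compounds below may be only part of what the source reports. "The series", "measured", "known", "first", "only" and "open" are said of these compounds alone.

Compound 1 `CC(C)(C)OC(=O)N1CCC(n2ncc3cc(-c4ccc(S(C)(=O)=O)cc4)ncc32)CC1` is the reference point of this set. In a functional assay on HEK293 cells for agonist activity at Glucose-dependent insulinotropic receptor (Homo sapiens), read by cAMP accumulation, with a stated time of 30 min (on this read-out higher numbers stand for an effect only at larger amounts of compound and lower numbers for an effect already at smaller amounts), compound 1 gives 20 nM, the lowest of the three numbers recorded. Compound 2 `CC(C)(C)OC(=O)N1CCC(n2nnc3cc(-c4ccc(S(C)(=O)=O)cc4)ccc32)CC1` gives in this assay a value of 63 nM, a step up from compound 1 that lies beyond the usual scatter. Compound 3 `CC(C)OC(=O)N1CCC(n2ncc3cc(Oc4ccc(S(C)(=O)=O)cc4)ncc32)CC1` gives in this assay a value of 177 nM, the furthest from compound 1 and also beyond the scatter. Compound 1 therefore stands as the most potent of the three measured compounds. Compound 4 `CC(C)CCN1CCC(n2ncc3cc(-c4ccc(S(C)(=O)=O)cc4)ncc32)CC1` has not yet been measured. It differs from compound 1 in one place: isopentyl in place of tert-butoxycarbonyl on an amine nitrogen in a ring. Among the compounds with values here, no measured pair in this set shows the effect of such a swap, so no measured step can guide the expectation directly; what can be said is that compound 1 carries the lowest number and the other two sit above it. The step from compound 1 to compound 4 is expected to be a 3.0-fold higher number from compound 1 to compound 4 (0.48 log units; beyond the scatter), a shift toward a somewhat higher number. Compound 4 is estimated at 60 nM in this assay. For compound 4 the expected range runs from 15 nM to 300 nM.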

Compound 4, half-maximal effective concentration: 220 nM
Estimate against measurement, compound 4: 3.7-fold (0.56 log units) below, and the stated range covers the measured number.
By their numbers in this assay, from the lowest: compound 1; then compound 2; then compounds 3 and 4 (each within the scatter of the next).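

In this assay, within the data shown here, the swap of tert-butoxycarbonyl for isopentyl on the amine nitrogen in a ring gives an 11-fold higher number from compound 1 to compound 4 (1.04 log units; beyond the scatter) and is a large change, the first single-place comparison in this set. It shows that the number depends strongly on the group at this nitrogen, even though both groups hold five carbon atoms and neither carries a ring, while only tert-butoxycarbonyl brings the two oxygen atoms and the double bond. No available measurement explains the rise.

Going by these compounds, it remains open whether the oxygen atoms, the double bond or the shape of the chain accounts for the step. Equally open, on these data alone, is how an ethoxycarbonyl group, an acetyl group or the free amine would fare at this nitrogen on the core of compound 1.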